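This account rests on a few compounds, and the source may have more. Where it says the series, first, only, none or still open, it means among the compounds named here.

Working notes on the series.

Compound 2 `O=C(NCCNc1nccc(-c2c(-c3cccc(F)c3)nc3sccn23)n1)c1ccc(Cl)cc1` carries a (4-chlorophenyl)carbonyl group on the amine nitrogen of the chain. Among the measured compounds shown here, in a functional assay on A-375 cells (Homo sapiens) for cytotoxicity, read by MTT assay (on this read-out lower numbers stand for stronger inhibition and higher numbers for weaker inhibition), compound 2 gives 2570 nM, the lowest of the two numbers so far. For the measured compounds named here, the only other measured member, compound 1 `Cc1ccc(S(=O)(=O)NCCNc2nccc(-c3c(-c4cccc(F)c4)nc4sccn34)n2)cc1`, bears a (4-methylphenyl)sulfonyl group at the same nitrogen; in this assay compound 1 gives 15400 nM. Going by the values given here, the single step between them, a 6.0-fold lower number from compound 1 to compound 2 (0.78 log units; beyond the scatter), is the whole of the measured ground for what follows.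

Compound 3 `O=S(=O)(NCCNc1nccc(-c2c(-c3cccc(F)c3)nc3sccn23)n1)c1cccc(F)c1` is not yet measured. Relative to compound 2 the change is (3-fluorophenyl)sulfonyl in place of (4-chlorophenyl)carbonyl on an amine nitrogen. Among the compounds with values here, it therefore runs the carbonyl-to-sulfonyl exchange in the direction opposite to the measured step, while the substitution on the aromatic ring also shifts from a 4-chloro to a 3-fluoro pattern, for which no separate step exists. Because a 6.0-fold lower number from compound 1 to compound 2 (0.78 log units; beyond the scatter) favoured the carbonyl, a return to a sulfonyl is expected to raise the number for compound 3, though the differing ring substituent leaves the size uncertain. For compound 3 the expected step is a 3.1-fold higher number from compound 2 to compound 3 (0.49 log units; beyond the scatter), giving an estimate of 8000 nM, with a range from 2500 nM to 25000 nM.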

Compound 3, half-maximal inhibitory concentration: 14900 nM
Estimate against measurement, compound 3: 1.9-fold (0.27 log units) below, within the range that was stated.
By their numbers in this assay, from the lowest: compound 2; then compounds 3 and 1 (each within the scatter of the next).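

In this assay the second sulfonyl member changes the picture: a 1.0-fold lower number from compound 1 to compound 3 (0.01 log units; within the scatter), so replacing 4-methylphenyl with 3-fluorophenyl on the sulfonyl sulfur leaves the number within the scatter, and this single ring change gives no sign of a gain or a loss. a 5.8-fold higher number from compound 2 to compound 3 (0.76 log units; beyond the scatter), a step close in size to the one first seen between the carbonyl and sulfonyl compounds, and among these three compounds the (4-chlorophenyl)carbonyl group of compound 2 stands alone at the low end, with no compound going against that. No measured evidence on hand explains these differences.

Compound 2 differs from both sulfonyl compounds in the linking group and in the ring substituent, so the compounds shown leave open whether the carbonyl alone accounts for the lower number or needs the 4-chloro pattern, a question that (3-fluorophenyl)carbonyl and (4-chlorophenyl)sulfonyl groups on the same amine nitrogen would separate. Also open, going by these compounds, is how the number responds to a urea in place of the amide, or to a longer chain between the core and that nitrogen.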